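The source may hold more compounds than are shown below. What is called first, only, known or untested is meant among the compounds shown, and "the series" means these compounds.

Measured so far in a physicochemical assay for solubility, measured as kinetic solubility, at pH 7.4; a higher number here means a more soluble compound, a lower number a less soluble compound:

- compound 1 `COc1cc(N2CCN(C(=O)C3CCC(O)CC3)CC2)ccc1Nc1nc(NC2CCCCC2)c2nc[nH]c2n1` gives 19000 nM
- compound 2 `COc1cc(N2CCC(C(=O)N3CCC(N(C)C)C3)CC2)ccc1Nc1nc(NC2CCCCC2)c2nc[nH]c2n1` gives 38000 nM
- compound 3 `COc1cc(N2CCC(C(=O)N3CCOCC3)CC2)ccc1Nc1nc(NC2CCCCC2)c2nc[nH]c2n1` gives 19000 nM

Compound 3 is level with compound 1 at the digits shown, and its gap to compound 2 lies within the scatter of repeat measurements. All three compounds therefore read much the same in this assay.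

The next compound is compound 4 `COc1cc(N2CCC(CC(=O)N3CCOCC3)CC2)ccc1Nc1nc(NC2CCCCC2)c2nc[nH]c2n1`. It has ((morpholin-4-yl)carbonyl)methyl in place of (morpholin-4-yl)carbonyl on a saturated ring carbon of the six-membered non-aromatic ring with 1 nitrogen: ((morpholin-4-yl)carbonyl)methyl in place of (morpholin-4-yl)carbonyl on a saturated ring carbon.

Within the data shown here, only one measured step bears on this, and only loosely. It is a 2.0-fold lower number from compound 2 to compound 3 (0.30 log units; within the scatter), a swap of the group on a carbonyl carbon, and it stays within the scatter. Among the measured compounds shown here, no measured pair shows the change made here, so the evidence is thin and the range must stay wide. No shift beyond the scatter is expected, and the estimated step is a 1.1-fold lower number from compound 3 to compound 4 (0.05 log units; within the scatter). For compound 4 the expected value is 17000 nM, with an estimated range of 7000 nM to 38000 nM.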

Compound 4, solubility: 19000 nM
Estimate against measurement, compound 4: 1.1-fold (0.05 log units) below, within the range that was stated.
By their numbers in this assay, from the lowest: compounds 1, 3, 4 and 2 (each within the scatter of the next).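

In this assay, ((morpholin-4-yl)carbonyl)methyl in place of (morpholin-4-yl)carbonyl on a saturated ring carbon gives no change at the digits printed from compound 3 to compound 4 (within the scatter), so this position tolerates the larger group, with 9 heavy atoms against 8, without a reading outside the scatter. Putting this group in place of (3-(dimethylamino)pyrrolidin-1-yl)carbonyl gives a 2.0-fold lower number from compound 2 to compound 4 (0.30 log units; within the scatter), which also stays within the scatter, so neither new step separates compound 4 from its neighbours. No measured property of these compounds is available to explain these readings.

On these data alone, it remains open whether a longer chain carrying the morpholine amide would also stay within the scatter at this saturated ring carbon. The same question holds for a carboxylic acid or a primary amine placed there instead of the amide.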